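This account rests on a few compounds, and the source may have more. Where it says the series, first, only, none or still open, it means among the compounds named here.

Measured compounds in a functional assay on A549 cells (Homo sapiens) for antiproliferative activity, read by MTT assay, with a stated time of 72 h; on this read-out higher numbers stand for weaker inhibition and lower numbers for stronger inhibition:
Compound 1 `C=C(Cl)C(=O)Nc1cc(Nc2ncc(C#N)c(-c3cn(C)c4ccccc34)n2)c(OC)cc1N(C)CCN(C)C` gives 133 nM.
Compound 2 `CC/C=C\C(=O)Nc1cc(Nc2ncc(C#N)c(-c3cn(C)c4ccccc34)n2)c(OC)cc1N(C)CCN(C)C` gives 162 nM.
Compound 3 `CCC/C=C\C(=O)Nc1cc(Nc2ncc(C#N)c(-c3cn(C)c4ccccc34)n2)c(OC)cc1N(C)CCN(C)C` gives 166 nM.

Compound 2 stands second highest of the three numbers; its nearest neighbour is compound 3 and its furthest is compound 1. The steps of a 1.2-fold higher number from compound 1 to compound 2 (0.09 log units; within the scatter) and a 1.2-fold higher number from compound 1 to compound 3 (0.10 log units; within the scatter) both replace the 1-chloroethenyl group on the carbonyl carbon and stay within the scatter, as does a 1.0-fold higher number from compound 2 to compound 3 (0.01 log units; within the scatter). On this read-out the three numbers cannot be told apart.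

Compound 4 `CC/C=C\C(=O)Nc1cc(Nc2ncc(C#N)c(-c3cn(C)c4ccc(F)cc34)n2)c(OC)cc1N(C)CCN(C)C` differs from compound 2 in one place: fluoro in place of hydrogen on an aromatic carbon. Within the data shown here, no measured step touches this part of the shared core; all three measured steps concern the substituent on the carbonyl carbon, and all of them were within the scatter. The series therefore gives no ground for a change beyond the scatter on this change, and the expected step of a 1.0-fold lower number from compound 2 to compound 4 (0.01 log units; within the scatter) is set to none beyond it. Among the measured compounds shown here, compound 4 is accordingly estimated at 160 nM in this assay, with a range from 70 nM to 360 nM, the width reflecting that no step of this kind has yet been measured.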

Compound 4, half-maximal inhibitory concentration: 4730 nM
For compound 4 the middle estimate is 30-fold (1.47 log units) below the measured one; the whole stated range lies below it.
By their numbers in this assay, from the lowest: compounds 1, 2 and 3 (each within the scatter of the next); then compound 4.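

In this assay, among these compounds, fluoro in place of hydrogen on an aromatic carbon of the 1-methyl-1H-indol-3-yl group gives a 29-fold higher number from compound 2 to compound 4 (1.47 log units; beyond the scatter), the first step beyond the scatter. The earlier steps, all at the substituent on the carbonyl carbon, left the numbers indistinguishable, whereas this change of 1 heavy atom, on a carbon meta to a fused ring and para to a fused ring, shows that this aromatic position is far less forgiving among the compounds shown. Nothing available explains why this small change has so large an effect on antiproliferative activity.

The compounds shown leave open whether the loss belongs to fluoro itself or would follow any replacement of hydrogen at this carbon, as a chloro, methyl, methoxy or amine group at the same place would tell. They also leave open whether 5-fluoro-1-methyl-1H-indol-3-yl brings a step of similar size when the carbonyl carbon carries 1-chloroethenyl or pent-1-en-1-yl instead of but-1-en-1-yl, and whether fluoro on the other carbons of that six-membered ring behaves the same way.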